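Permeability across the aryl-amino end of the series

This account rests on a few compounds, and the source may have more. Where it says the series, first, only, none or still open, it means among the compounds named here.

Three members of the series carry the same core and differ only in the aryl group on the ring nitrogen. Compound 1 `CNC(=O)c1cc(Oc2ccc3oc(Nc4ccccc4Cl)nc3c2)ccn1` gives 10 10^-6 cm/s in an ADME assay on Caco-2 cells (Homo sapiens) for permeability, in the apical to basolateral direction; on this read-out lower numbers stand for lower permeability and higher numbers for higher permeability. Compound 2 `CCc1ccccc1Nc1nc2cc(Oc3ccnc(C(=O)NC)c3)ccc2o1` gives 10 10^-6 cm/s in this assay , and compound 3 `CNC(=O)c1cc(Oc2ccc3oc(Nc4cccc(C(C)C)c4)nc3c2)ccn1` gives 10 10^-6 cm/s. Compound 2 therefore stands level with compounds 1 and 3 at the digits shown: the step of no change at the digits printed from compound 1 to compound 2 (within the scatter), the step of no change at the digits printed from compound 1 to compound 3 (within the scatter) and the step of no change at the digits printed from compound 2 to compound 3 (within the scatter) all stay within the scatter.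

Compound 4 `CNC(=O)c1cc(Oc2ccc3oc(Nc4ccc(Br)cc4)nc3c2)ccn1` has not yet been measured in this assay . It differs from compound 2 in one place: 4-bromophenyl in place of 2-ethylphenyl on a nitrogen on an aromatic ring. All three measured steps change the same aryl group, and each of them left the read-out unchanged; halogen on the ring (compound 1) and alkyl on the ring (compounds 2 and 3) gave the same numbers. Within the data shown here, no step here tells against a flat result for a further exchange at this position.

Compound 4 is therefore expected to give about 10 10^-6 cm/s in this assay , with a range of 5 10^-6 cm/s to 20 10^-6 cm/s. The estimated step of no change at the digits printed from compound 2 to compound 4 (within the scatter) means no change beyond the scatter.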

Compound 4, apparent permeability: 10 10^-6 cm/s
Compound 4: middle estimate and measured number agree at the digits printed; the range from low to high includes it.
By their numbers in this assay, from the lowest: compounds 1, 2, 3 and 4 (each within the scatter of the next).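

In this assay the 4-bromophenyl group on the nitrogen keeps the read-out level with each earlier aryl group, with no change at the digits printed from compound 2 to compound 4 (within the scatter), no change at the digits printed from compound 3 to compound 4 (within the scatter) and no change at the digits printed from compound 1 to compound 4 (within the scatter). Among these compounds, compound 4 is the only one of the four with bromine, and the flat result now holds across 2-chlorophenyl, 2-ethylphenyl, 3-isopropylphenyl and 4-bromophenyl, with no compound here going against it. No supporting data on the compounds are available to explain this flat result.

From the compounds shown here alone, all four groups are phenyl rings carrying a single halogen or alkyl substituent, so it remains open whether the read-out stays level with an amine or a carboxylic acid on that ring, or with a longer chain in place of the ring. Every compound here also keeps the same core and the same amide end, so nothing yet shows how this read-out responds to a change at either of those places.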